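A few compounds are considered here, and "the series" means these few. Any claim that something is new, unique, unknown or untested is made for them only; others in the source may bear on it.

In an in vitro assay on LLC-PK1 cells for displacement of a labelled ligand from growth hormone secretagogue receptor type 1 (Homo sapiens) (on this read-out higher numbers stand for weaker inhibition and lower numbers for stronger inhibition), three close relatives of the same core have been measured. Compound 1 `COc1ccc(Cn2c(CCc3ccccc3)nnc2[C@H](NC(=O)c2ccccn2)c2c[nH]c3ccccc23)c(OC)c1` gives 1.1 nM. Compound 2 `COc1ccc(Cn2c(CCc3ccccc3)nnc2[C@H](NC(=O)c2ccncc2)c2c[nH]c3ccccc23)c(OC)c1` gives 58 nM. Compound 3 `COc1ccc(Cn2c(CCc3ccccc3)nnc2[C@H](NC(=O)c2ccccc2)c2c[nH]c3ccccc23)c(OC)c1` gives 11.8 nM, which places it second highest of the three numbers: the step of a 4.9-fold lower number from compound 2 to compound 3 (0.69 log units; beyond the scatter) is modest, while the step of an 11-fold higher number from compound 1 to compound 3 (1.03 log units; beyond the scatter) is large, so compound 1 sits well apart from the other two.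

Compound 4 `COc1ccc(Cn2c(CCc3ccccc3)nnc2[C@H](NCc2ccccc2)c2c[nH]c3ccccc23)c(OC)c1` differs from compound 3 by benzyl in place of benzoyl on an amine nitrogen. The three measured steps, a 53-fold higher number from compound 1 to compound 2 (1.72 log units; beyond the scatter), an 11-fold higher number from compound 1 to compound 3 (1.03 log units; beyond the scatter) and a 4.9-fold lower number from compound 2 to compound 3 (0.69 log units; beyond the scatter), all swap one six-membered aromatic ring for another on the carbonyl carbon and leave the carbonyl itself untouched. Within the data shown here, none of them removes the carbonyl, so no measured step speaks directly to the change from compound 3 to compound 4. What these steps do show is that changes at this part of the molecule move the numbers well beyond the scatter, in both directions. With the carbonyl gone and an acceptor lost, a shift beyond the scatter is expected, and a higher number is judged more likely than a lower one, though the direction is uncertain. Compound 4 is therefore estimated at 80 nM, within 8 nM to 800 nM, meaning an expected step of a 6.8-fold higher number from compound 3 to compound 4 (0.83 log units; beyond the scatter).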

Compound 4, half-maximal inhibitory concentration: > 1000 nM
Compound 4: no number, only a limit; the forecaster's own chance of this, stated with the estimate: 5%; at least 12-fold (1.09 log units) between middle value and limit.
By their numbers in this assay, from the lowest: compound 1; then compound 3; then compound 2. At a limit, above all of these: compound 4.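

Compound 4 has no exact number in this assay, only a limit of the assay: the limit of > 1000 nM in this assay, at which 1 of the 4 values shown sits.

Even so, the result answers something the earlier compounds could not, since they all kept the carbonyl and changed only the ring on it, whereas here the six-membered aromatic ring of carbon stays and the carbonyl goes, leaving benzyl in place of benzoyl on the amine nitrogen, with an at least 84-fold higher number from compound 3 to compound 4 (1.92 log units; beyond the scatter) in the weaker direction. The loss holds against the other two amides as well, with an at least 17-fold higher number from compound 2 to compound 4 (1.23 log units; beyond the scatter) and an at least 900-fold higher number from compound 1 to compound 4 (2.95 log units; beyond the scatter), so among these compounds the carbonyl itself matters for inhibition, and not only the ring it carries.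

The compounds shown leave open whether another linking group on this nitrogen, such as a urea, a carbamate or a sulfonamide, would keep the number close to that of compound 3. They also leave open whether a (pyridin-2-yl)methyl group, the counterpart of compound 1 without the carbonyl, would fall as far as benzyl does, and how far compound 4 really lies beyond its limit.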